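Swapping the Ring on the Sulfonamide Nitrogen

This account rests on a few compounds, and the source may have more. Where it says the series, first, only, none or still open, it means among the compounds named here.

Within the data shown here, compound 1 `O=C(COc1ccc(F)cc1)N1CCc2cc(S(=O)(=O)Nc3nccs3)ccc21` is one of two compounds measured in an assay on cells for inhibition of sodium channel protein type 3 subunit alpha (Homo sapiens), read by electrophysiology; a higher number here means a weaker inhibitor, a lower number a stronger inhibitor. In this assay compound 1 gives 2510 nM, the lower of the two numbers. The other, compound 2 `O=C(c1ccc(S(=O)(=O)Nc2ncns2)c(F)c1)N1CCC(c2ccnc(C(F)(F)F)n2)CC1`, is built on a different core and in this assay gives 6680 nM, a number that lies beyond the usual scatter from that of compound 1; as the two differ in several places at once, only their values can be set side by side.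

Compound 3 `O=C(COc1ccc(F)cc1)N1CCc2cc(S(=O)(=O)Nc3ncns3)ccc21` keeps everything in compound 1 except one ring: 1,2,4-thiadiazol-5-yl in place of 1,3-thiazol-2-yl on a sulfonamide nitrogen. Among the measured compounds shown here, no measured pair here isolates this exact swap, so the expectation rests on the change itself and on compound 1 giving 2510 nM. A modest gain is expected, a step that may still fall within the scatter, and the estimated step of a 1.9-fold lower number from compound 1 to compound 3 (0.29 log units; within the scatter) points toward a lower number. Compound 3 is therefore expected to give 1300 nM in this assay, within a range from 400 nM to 4000 nM.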

Compound 3, half-maximal inhibitory concentration in the sodium channel protein type 3 subunit alpha assay: 1270 nM
Beside the measured number, compound 3's estimate is 1.0-fold (0.01 log units) above it; measured number inside the range.
By their numbers in the sodium channel protein type 3 subunit alpha assay, from the lowest: compounds 3 and 1 (each within the scatter of the next); then compound 2.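

In the sodium channel protein type 3 subunit alpha assay, placing 1,2,4-thiadiazol-5-yl in place of 1,3-thiazol-2-yl on the sulfonamide nitrogen gives a 2.0-fold lower number from compound 1 to compound 3 (0.30 log units; within the scatter), so this assay does not tell the two compounds apart. In a physicochemical assay for lipophilicity (a lower number here means a more polar compound, a higher number a more lipophilic compound), compound 1 gives 1.8 and compound 3 gives 0.4. In the physicochemical assay, the same swap gives a number 1.40 log units lower from compound 1 to compound 3 (beyond the scatter), a clear shift from a change of one ring of the same size. This position therefore accepts a swap that leaves compound 3 measurably more polar than compound 1, with no difference beyond the scatter in the sodium channel protein type 3 subunit alpha assay: the measured distribution coefficient of compound 1, 1.8, and of compound 3, 0.4, a number 1.40 log units lower (beyond the scatter)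

On these data alone, whether a six-membered ring such as pyridin-2-yl, or a plain methyl group, on the same sulfonamide nitrogen would also hold the reading in the sodium channel protein type 3 subunit alpha assay stays open. As far as these compounds go, compound 2 carries 1,2,4-thiadiazol-5-yl on a different core, so it also remains open whether this swap would behave the same way outside the core of compound 1.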